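A Fluoro Analog of a Stilbene-Type Antiproliferative Compound

The compounds below may be only part of what the source reports. "The series", "measured", "known", "first", "only" and "open" are said of these compounds alone.

Measured so far:
compound 1 `C=C(/C(C)=C/c1ccc(OC)c(O)c1)c1cc(OC)c(OC)c(OC)c1`: 61 nM
compound 2 `CC=C(/C(C)=C/c1ccc(OC)c(O)c1)c1cc(OC)c(OC)c(OC)c1`: 789 nM

In a functional assay on PC-3 cells (Homo sapiens) for antiproliferative activity, read by MTT assay, with a stated time of 48 h (a lower number here means a stronger inhibitor, a higher number a weaker inhibitor), compound 1 gives 61 nM, the lower of the two numbers. Compound 2 gives 789 nM, and a 13-fold higher number from compound 1 to compound 2 (1.11 log units; beyond the scatter). Compound 3 `C=C(/C(C)=C/c1ccc(OC)c(F)c1)c1cc(OC)c(OC)c(OC)c1` differs from compound 1 by fluoro in place of hydroxy on an aromatic carbon. Going by the values given here, the single measured step concerns a different place on the shared core, so it offers no direct guide to this change. With nothing in the numbers pointing either way, for compound 3 a step within the scatter is expected, a 1.6-fold higher number from compound 1 to compound 3 (0.21 log units; within the scatter). Compound 3 is therefore estimated at 100 nM, with a range from 30 nM to 400 nM.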

Compound 3, half-maximal inhibitory concentration: 354 nM
Compound 3: the middle estimate sits 3.5-fold (0.55 log units) below what was measured, within the range that was stated.
By their numbers in this assay, from the lowest: compound 1; then compound 3; then compound 2.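

Replacing hydroxy with fluoro on this aromatic carbon gives a 5.8-fold higher number from compound 1 to compound 3 (0.76 log units; beyond the scatter) in this assay. This position therefore responds to the group it carries, a sensitivity that the earlier step, made elsewhere on the shared core, could not reveal. Fluoro has neither the hydrogen-bond donor nor the hydrogen-bond acceptor counted for hydroxy, but no measurement here links that difference to the loss of activity. Still open, going by these compounds, is how an amine or a chloro group on this carbon would compare with hydroxy and fluoro. Also open, on these data alone, is whether the same swap would have a similar effect on the core of compound 2.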